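This account rests on a few compounds, and the source may have more. Where it says the series, first, only, none or still open, it means among the compounds named here.

The series shares one core, a saturated ring fused to a benzene that carries a propargylamine on one side and a sulfur-linked arylalkyl group on the other. Compound 1 `C#CCNC1CCc2c(SCc3cccc(C)c3)cccc21`, which bears a 3-methylphenyl on a one-carbon link, returned only a limit in an assay on isolated protein for inhibition of Amine oxidase [flavin-containing] B (Homo sapiens); on this read-out higher numbers stand for weaker inhibition and lower numbers for stronger inhibition: the value for compound 1, > 100000 nM, is a limit of the assay and not a number. Compound 2 `C#CCNC1CCc2c(SCCc3ccc(Cl)cc3)cccc21`, with a 4-chlorophenyl on a two-carbon link, gives 10800 nM in this assay. Compound 3 `C#CCNC1CCc2c(SCc3ccc(Cl)c(Cl)c3)cccc21`, with a 3,4-dichlorophenyl on a one-carbon link, gives 2840 nM in this assay. Of the two real numbers, compound 2 stands at the higher one, and its gap to compound 3 lies beyond the scatter, so compound 3 inhibits more strongly.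

Compound 4 `C#CCNC1CCc2c(SCCc3cccc(OC)c3)cccc21` differs from compound 2 by 3-methoxyphenyl in place of 4-chlorophenyl on a saturated chain carbon, two bonds along the chain from a sulfur. Among the compounds with values here, no pair of measured compounds carries this change, so the expectation rests on the wider picture: the only other compound with a single substituent in the 3-position of the phenyl, compound 1, sits at the limit (the limit of > 100000 nM in this assay, at which 1 of the 3 values shown sits). In this assay the step is therefore expected to be a 2.6-fold higher number from compound 2 to compound 4 (0.41 log units; beyond the scatter), toward weaker inhibition and beyond the scatter. Compound 4 is thus expected to give about 28000 nM in this assay, with a likely range from 7000 nM to 100000 nM.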

Compound 4, half-maximal inhibitory concentration: 28700 nM
Compound 4: the middle estimate sits 1.0-fold (0.01 log units) below what was measured, and the stated range covers the measured number.
By their numbers in this assay, from the lowest: compound 3; then compound 2; then compound 4. At a limit, above all of these: compound 1.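

On the two-carbon link, the exchange of 4-chlorophenyl for 3-methoxyphenyl gives the series its first step between compounds that differ in one place: in this assay, the change is a 2.7-fold higher number from compound 2 to compound 4 (0.42 log units; beyond the scatter), toward weaker inhibition and beyond the scatter. The step shows that the aryl group on this saturated chain carbon bears on inhibition, although the exchange alters both the substituent and its place on the phenyl, so neither can be credited alone, and compound 4 still returns a real number. Compound 1 remains the one limit in the set, and that limit gives no number to set against this step: the limit of > 100000 nM in this assay, at which 1 of the 4 values shown sits.

A 3-chlorophenyl or a 4-methoxyphenyl on the same two-carbon link would separate the effect of the substituent from that of its place on the phenyl. As far as these compounds go, the part played by the link itself also stays open, and a pair sharing one aryl group on a one-carbon and a two-carbon link, or a longer chain such as a three-carbon link, would bear on it.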